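The source may report more compounds than this note shows. Statements on the series, on what has been measured and on what is new or still open speak of the compounds shown alone.

Series notes. Compound 1 `Oc1cccc(CNc2cc(Br)cc3[nH]ncc23)c1` is measured in an assay for inhibition of Tryptophan 2,3-dioxygenase (Homo sapiens), with a stated time of 1 h, tested at 10 uM; on this read-out higher numbers stand for more inhibition at the one concentration tested (going by the name of the read-out) and lower numbers for less inhibition; compound 1 gives 55%. Compound 3 `Brc1cc(NCc2ccncc2)c2cn[nH]c2c1` stands level with it: in this assay compound 3 gives 55%, no change at the digits shown and within the scatter. Compound 2 `Oc1ccc(CNc2cc(Br)cc3[nH]ncc23)cc1O` is reported in this assay only as "not active" (no number reported), without a number. Compound 4 `O=C(O)Nc1cccc(CNc2cc(Br)cc3[nH]ncc23)c1` is not yet measured; it differs from compound 1 by carboxyamino in place of hydroxy on an aromatic carbon. Among the compounds with values here, no step between measured compounds addresses this change, so the direction is uncertain; a modest downward step is expected, near the edge of the scatter, a number 15 percentage points lower from compound 1 to compound 4 (beyond the scatter). In this assay compound 4 is estimated at 40%, with a range from 10% to 65%.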

Compound 4, a percentage reported as inhibition, at one concentration (the size of the read-out at that concentration, not a potency): "not active" (no number reported)
No number was reported for compound 4, so the estimate cannot be set against anything.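

Within the data shown here, compound 4 is reported in this assay as "not active" (no number reported), so no step from compound 1 can be read. Going by these compounds, how far carboxyamino in place of hydroxy shifts inhibition stays open. No evidence on hand bears on this result.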